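The source may report more compounds than this note shows. Statements on the series, on what has been measured and on what is new or still open speak of the compounds shown alone.

Measured so far in an assay on isolated protein for inhibition of Gonadotropin-releasing hormone receptor (Homo sapiens); on this read-out higher numbers stand for weaker inhibition and lower numbers for stronger inhibition:
- compound 1 `COc1ccc([N+](=O)[O-])cc1CSc1nc2cc(NC(=O)NC(C)(C)C)ccc2n1C1CC1`: 79 nM
- compound 2 `CCn1c(SCc2cc([N+](=O)[O-])ccc2OC)nc2cc(NC(=O)NC(C)(C)C)ccc21`: 42 nM
- compound 3 `CCCn1c(SCc2cc([N+](=O)[O-])ccc2OC)nc2cc(NC(=O)NC(C)(C)C)cc(C(=O)OC)c21`: 37 nM

Compound 3 carries a methoxycarbonyl on the shared core that compound 1 and compound 2 lack. Its number in this assay and that of compound 2 lie within the scatter of each other, so no order between them is claimed; against compound 1 the gap is beyond the scatter, compound 3 giving the lower number. Among the compounds with values here, the only single-point step measured, a 1.9-fold lower number from compound 1 to compound 2 (0.27 log units; within the scatter), concerns the substituent on the aromatic nitrogen and does not touch the carbonyl position.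

Compound 4 `CCCn1c(SCc2cc([N+](=O)[O-])ccc2OC)nc2cc(NC(=O)NC(C)(C)C)cc(C(=O)NC(C)(C)C)c21` is compound 3 with (tert-butyl)amino in place of methoxy on a carbonyl carbon. Within the data shown here, no measured pair varies this carbonyl substituent, and the step from compound 1 to compound 2 gives no guidance on it. Compound 2, which carries no substituent at that position at all, sits within the scatter of compound 3, which suggests the position tolerates change without a large shift. The expectation for compound 4 in this assay is therefore no step beyond the scatter, a 1.1-fold higher number from compound 3 to compound 4 (0.03 log units; within the scatter), with the range widened for the absence of direct precedent. Compound 4 is estimated at 40 nM, between 12 nM and 130 nM.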

Compound 4, half-maximal inhibitory concentration: 410 nM
Compound 4: middle estimate off by 10-fold (1.01 log units), on the low side, outside the stated range (above it).
By their numbers in this assay, from the lowest: compounds 3, 2 and 1 (each within the scatter of the next, the first and the last beyond it); then compound 4.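

In this assay, within the data shown here, this is the first measured pair that varies the group on this carbonyl carbon, and the change from methoxy to (tert-butyl)amino gives an 11-fold higher number from compound 3 to compound 4 (1.04 log units; beyond the scatter), so the position is not indifferent to what it carries when the rest of compound 3 is held fixed. The change alters several counted features at once: 2 heavy atoms leave and 5 enter, 1 hydrogen-bond acceptor leaves and 1 hydrogen-bond donor enters, and the ester link gives way to an amide link, so this single step does not separate their contributions. Nothing on hand bears on the reason for the step.

Still open, going by these compounds, is whether the higher number goes with the tert-butyl group or with the amide hydrogen; tert-butoxy, methylamino and dimethylamino on the same carbonyl carbon would pull these apart. Also open, on these data alone, is how a carboxylic acid at this place would read, and whether the step from methoxy to (tert-butyl)amino keeps its size with ethyl instead of propyl on the aromatic nitrogen.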